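A few compounds are considered here, and "the series" means these few. Any claim that something is new, unique, unknown or untested is made for them only; others in the source may bear on it.

The study centres on a small set of anilines bearing a ketone-linked amide side chain, examined in a functional assay for inhibition of kynurenine 3-monooxygenase (Rattus norvegicus), tested at 1 mM; a higher number here means more inhibition at the concentration tested (going by the name of the read-out), a lower number less inhibition. Compound 1 `CCC(=O)NCCC(=O)c1cc(OC)ccc1N` gives 99.4% in this assay, and compound 2 `COc1ccc(N)c(C(=O)CCNC(=O)C2CCCCC2)c1` gives 99.6%. A third member, compound 3 `CC(=O)NCCC(=O)c1cc(Cl)ccc1N`, has "not determined" (no result reported) in this assay. Between compound 1 and compound 2 the only change is cyclohexyl in place of ethyl on a carbonyl carbon, and the step of a number 0.2 percentage points higher from compound 1 to compound 2 (within the scatter) is within the scatter. On the numbers shown, compound 2 stands highest of the two reported figures, with compound 1 nearest and within the scatter of it, so the two cannot be ordered.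

The next compound, compound 4 `COc1ccc(N)c(C(=O)CCNC(=O)c2ccccc2)c1`, differs from compound 2 only as follows: phenyl in place of cyclohexyl on a carbonyl carbon. Going by the values given here, the single measured step that bears on a change at this carbonyl carbon is that from compound 1 to compound 2, which lay within the scatter, so the expected step of a number 1.6 percentage points lower from compound 2 to compound 4 (within the scatter) is none beyond the scatter. Compound 4 is therefore estimated at 98%, within a range from 90% to 100%.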

Compound 4, a percentage reported as inhibition, at one concentration (the size of the read-out at that concentration, not a potency): 97.2%
Compound 4: the middle estimate sits 0.8 percentage points above what was measured; the range from low to high includes it.
By their numbers in this assay, from the lowest: compounds 4, 1 and 2 (each within the scatter of the next).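

In this assay the carbonyl carbon of the amide now carries an aromatic ring, and cyclohexyl giving way to phenyl produces a number 2.4 percentage points lower from compound 2 to compound 4 (within the scatter), while phenyl in place of ethyl produces a number 2.2 percentage points lower from compound 1 to compound 4 (within the scatter). Ethyl, cyclohexyl and phenyl on this carbonyl carbon therefore cannot be told apart at the concentration tested, whether the six-membered ring is aromatic or not. No evidence is available that bears on this result.

Going by these compounds, it remains open whether a group of another kind on this carbonyl carbon, such as an amine or a carboxylic acid, would move the read-out beyond the scatter. With all three numbers lying this close at a single concentration, the compounds also leave open how they would compare as potencies.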